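A Furan-2-yl Replacement on a Shared Insecticidal Core

This account rests on a few compounds, and the source may have more. Where it says the series, first, only, none or still open, it means among the compounds named here.

For the measured compounds named here, compound 2 `CC(C)(C)n1ncc(OCc2nnc(-c3ccc(Cl)cc3F)o2)c(Cl)c1=O` was tested in a functional assay on the whole organism for inhibition, with Mythimna separata as the target, with a stated time of 5 days (a higher number here means that more compound is needed for the effect, a lower number that less compound is needed), and gives 10400 nM, the highest of the two numbers so far, though its only neighbour lies within the scatter of it. That neighbour, compound 1 `CC(C)(C)n1ncc(OCc2nnc(-c3ccc(F)cc3)o2)c(Cl)c1=O`, gives 5200 nM in this assay, and the step of a 2.0-fold higher number from compound 1 to compound 2 (0.30 log units; within the scatter) stays within the scatter. Compound 3 `CC(C)(C)n1ncc(OCc2nnc(-c3ccco3)o2)c(Cl)c1=O` has not yet been measured. The change from compound 2 to compound 3 is furan-2-yl in place of 4-chloro-2-fluorophenyl on an aromatic carbon. Going by the values given here, only one measured step touches this place on the core, a 2.0-fold higher number from compound 1 to compound 2 (0.30 log units; within the scatter), and it exchanged one six-membered aromatic ring of carbon only for another; no measured step exchanges such a ring for a five-membered aromatic ring with 1 hetero atom. Among the compounds with values here, the one step that exists was within the scatter, so the step of a 1.3-fold lower number from compound 2 to compound 3 (0.11 log units; within the scatter) in this assay is expected to be no larger than the scatter, with a wide range because the ring type itself is new. Compound 3 is therefore estimated at 8000 nM, between 2500 nM and 25000 nM.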

Compound 3, half-maximal effective concentration: > 299000 nM
Compound 3 gave a limit, no number (the forecaster's own chance of this, stated with the estimate: 10%); middle value at least 37-fold (1.57 log units) away from the limit.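

In this assay, the result for compound 3 is a limit and not a number: the limit of > 299000 nM in this assay, at which 1 of the 3 values shown sits. Even read as a limit, it shows that this position on the shared core is far from indifferent to the group it carries, since furan-2-yl in place of the phenyl groups gives an at least 28-fold higher number from compound 2 to compound 3 (1.45 log units; beyond the scatter) and an at least 57-fold higher number from compound 1 to compound 3 (1.75 log units; beyond the scatter), both large and beyond the scatter. For the compounds shown here, the earlier exchange of 4-fluorophenyl for 4-chloro-2-fluorophenyl, a 2.0-fold higher number from compound 1 to compound 2 (0.30 log units; within the scatter), stayed within the scatter, so it showed only that these two six-membered aromatic rings of carbon only cannot be told apart here, while the move to a five-membered aromatic ring with 1 hetero atom is the first change at this place to register clearly.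

This one change alters the ring size, brings in the ring oxygen and removes the halogens all at once, so the compounds shown cannot say which of these matters, and the full size of the step stays unknown behind the limit. Going by these compounds, how an unsubstituted phenyl, a thiophen-2-yl or a chlorine-bearing furan-2-yl would stand at this place remains open.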